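Swapping One Halogen Pattern for Another on the Ring Group

The source may hold more compounds than are shown below. What is called first, only, known or untested is meant among the compounds shown, and "the series" means these compounds.

Compound 2 `Nc1scc(CN2CCN(c3cc(F)cc(F)c3)CC2)c1C(=O)c1ccc(Cl)cc1` is one of two close relatives measured in a functional assay on CHO cells with adenosine receptor A1 (Homo sapiens) as the target, read by cAMP accumulation and immunoassay, with a stated time of 6 min, tested at 10 uM; on this read-out lower numbers stand for a stronger effect and higher numbers for a weaker effect at the one concentration tested. In this assay compound 2 gives -79%, the higher of the two numbers available. Its neighbour, compound 1 `Nc1scc(CN2CCN(c3ccc(F)c(F)c3)CC2)c1C(=O)c1ccc(Cl)cc1`, gives -87% in this assay, and the step between them, a number 8 percentage points higher from compound 1 to compound 2 (within the scatter), stays within the scatter of repeated measurements, so the two compounds cannot be told apart on these numbers.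

Compound 3 `Nc1scc(CN2CCN(c3ccc(F)c(Cl)c3)CC2)c1C(=O)c1ccc(Cl)cc1` has not yet been measured. It differs from compound 2 in one place: 3-chloro-4-fluorophenyl in place of 3,5-difluorophenyl on an amine nitrogen in a ring. Among the compounds with values here, the only measured step that bears on this change is a number 8 percentage points higher from compound 1 to compound 2 (within the scatter), which also exchanged one such ring group for another and produced no shift beyond the scatter. Because compound 1 gives -87% and compound 2 gives -79% in this assay, the step of a number 3 percentage points lower from compound 2 to compound 3 (within the scatter) is expected to be small, with no clear direction beyond the scatter. Compound 3 is therefore estimated to give about -82% in this assay, within a range from -96% to -64%.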

Compound 3, a percentage reported as activity, at one concentration (the size of the read-out at that concentration, not a potency): -78%
For compound 3 the middle estimate is 4 percentage points below the measured one, within the range that was stated.
By their numbers in this assay, from the lowest: compounds 1, 2 and 3 (each within the scatter of the next).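

In this assay the exchange of 3,5-difluorophenyl for 3-chloro-4-fluorophenyl on an amine nitrogen in a ring gives a number 1 percentage points higher from compound 2 to compound 3 (within the scatter) and the change of chloro in place of fluoro on an aromatic carbon gives a number 9 percentage points higher from compound 1 to compound 3 (within the scatter) as well. The earlier pair showed only that the two fluoro atoms could be arranged differently on this ring group, whereas these steps show that a chloro group can also stand on it without a shift beyond the scatter, so the three compounds cannot be told apart on these numbers. No measurement shown here offers an explanation for this result.

All three compounds carry only halogens on this phenyl ring, which leaves open whether a different group there, such as methoxy, a nitrile or an amine, would stay within the scatter or move the read-out beyond it. On these data alone, every number also comes from a single concentration, so how these compounds would compare across a range of concentrations remains open too.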